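Exchanging the Aryl Group on the Sulfonyl Sulfur

This account rests on a few compounds, and the source may have more. Where it says the series, first, only, none or still open, it means among the compounds named here.

Measured compounds:
compound 1 `Cc1ccc(S(=O)(=O)c2cnc3cc(F)ccc3c2N2CCC(C)CC2)cc1C`: 90%
compound 2 `COc1ccc(S(=O)(=O)c2cnc3ccc(C)cc3c2N2CCC(C)CC2)cc1Cl`: 93%
compound 3 `Cc1ccc(S(=O)(=O)c2cnc3ccc(F)cc3c2N2CCC(C)CC2)cc1C`: 92%

In an assay on isolated protein for displacement of a labelled ligand from metabotropic glutamate receptor 5 (Homo sapiens), with a stated time of 60 min, tested at 1 uM (on this read-out lower numbers stand for less inhibition and higher numbers for more inhibition at the one concentration tested (going by the name of the read-out)), compound 1 gives 90%, the lowest of the three numbers, but the neighbours sit close by. Compound 3 gives 92% and compound 2 gives 93% in this assay, and both lie within the scatter of compound 1, so the three compounds cannot be ordered against one another.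

Compound 4 `CC1CCN(c2c(S(=O)(=O)c3ccc(C#N)cc3)cnc3cc(F)ccc23)CC1` differs from compound 1 in one place: 4-cyanophenyl in place of 3,4-dimethylphenyl on a sulfonyl sulfur. Among the measured compounds shown here, no measured pair shows this exchange, so its effect is open. Since all three measured compounds sit high in this assay, a downward step of about the scatter's size, or none beyond it, is expected. Compound 4 is therefore expected to give about 80%, between 55% and 95%. The expected step of a number 10 percentage points lower from compound 1 to compound 4 (within the scatter) is estimated to be small.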

Compound 4, a percentage reported as inhibition, at one concentration (the size of the read-out at that concentration, not a potency): 83%
Compound 4: middle estimate off by 3 percentage points, on the low side; measured number inside the range.
By their numbers in this assay, from the lowest: compounds 4, 1, 3 and 2 (each within the scatter of the next).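

Read in this assay, the exchange gives a number 7 percentage points lower from compound 1 to compound 4 (within the scatter), so on the sulfonyl sulfur 4-cyanophenyl and 3,4-dimethylphenyl cannot be told apart. Among the compounds shown here, this is the first look at this place, and it shows that an aryl group bearing a nitrile, with its hydrogen-bond acceptor, can stand there with the number still in the range of the other compounds. Nothing measured here explains the step. Going by these compounds, whether a carboxylic acid or an amine on the aryl group, or a cyclohexyl group in its place, would give a step beyond the scatter remains open.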